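Isobutyl for pentan-3-yl on the ring nitrogen

The compounds below may be only part of what the source reports. "The series", "measured", "known", "first", "only" and "open" are said of these compounds alone.

Compound 1 `CCC(CC)n1c(-c2ccc(OCc3c(-c4c(Cl)cccc4Cl)noc3C(C)C)cc2)nc2ccc(C(=O)O)cc21` is the anchor of this set; in an assay on isolated protein for agonist activity at Bile acid receptor (Homo sapiens), read by TR-FRET (on this read-out higher numbers stand for an effect only at larger amounts of compound and lower numbers for an effect already at smaller amounts), compound 1 gives 26.5 nM. Compound 2 `CC(C)c1onc(-c2c(Cl)cccc2Cl)c1COc1ccc(-c2nc3ccc(C(=O)O)cc3n2C2CC2)cc1` differs by cyclopropyl in place of pentan-3-yl on an aromatic nitrogen, and in this assay compound 2 gives 117 nM, a step of a 4.4-fold higher number from compound 1 to compound 2 (0.64 log units; beyond the scatter). Compound 3 `CC(C)c1onc(-c2c(Cl)cccc2Cl)c1COc1ccc(-c2nc3ccc(C(=O)O)cc3n2C2CCC2)cc1` carries the cyclobutyl analogue of that nitrogen substituent, but in this assay compound 3 gives "not determined" (no result reported), so it adds no number. Going by the values given here, compound 1 therefore stands lowest of the two numbers available, with compound 2 as its only measured neighbour.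

Compound 4 `CC(C)Cn1c(-c2ccc(OCc3c(-c4c(Cl)cccc4Cl)noc3C(C)C)cc2)nc2ccc(C(=O)O)cc21` is the next point. Relative to compound 1 the change is isobutyl in place of pentan-3-yl on an aromatic nitrogen.

Among the compounds with values here, only the step from compound 1 to compound 2 bears on this change: both replace pentan-3-yl on the same aromatic nitrogen, and that step was modest but beyond the scatter. Isobutyl, again without a ring, is a less drastic departure from pentan-3-yl than cyclopropyl, so for compound 4 a smaller upward step than that of a 4.4-fold higher number from compound 1 to compound 2 (0.64 log units; beyond the scatter) is expected, around a 1.9-fold higher number from compound 1 to compound 4 (0.28 log units; within the scatter). Compound 4 is thus estimated at 50 nM in this assay, with a range of 20 nM to 130 nM.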

Compound 4, half-maximal effective concentration: 24.7 nM
The estimate for compound 4 lay 2.0-fold (0.31 log units) above the measured number; the measured number falls inside the stated range.
By their numbers in this assay, from the lowest: compounds 4 and 1 (each within the scatter of the next); then compound 2.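

Isobutyl in place of pentan-3-yl on the aromatic nitrogen gives a 1.1-fold lower number from compound 1 to compound 4 (0.03 log units; within the scatter), so in this assay the open-chain substituent can go from 5 heavy atoms to 4 carbon atoms with no change beyond the scatter. Isobutyl in place of cyclopropyl gives a 4.7-fold lower number from compound 2 to compound 4 (0.68 log units; beyond the scatter), which shows that the higher number of compound 2 does not simply follow from a substituent smaller than pentan-3-yl: among the three compounds with numbers, the two without a ring on this nitrogen stay together, and compound 2, the only one with a ring, stands apart. No measurement here explains why compound 2 departs from compound 1 and compound 4.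

From the compounds shown here alone, whether a ring on this nitrogen generally goes with a higher number remains open, as that reading rests on compound 2 alone and compound 3 gives no result. Also open is how far this position accepts other groups, such as a longer chain like n-hexyl, a benzyl group or a chain ending in an amine, since the compounds shown cover only small hydrocarbon substituents.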